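Methoxy addition on two cores: expectation for compound 4

The source may hold more compounds than are shown below. What is called first, only, known or untested is meant among the compounds shown, and "the series" means these compounds.

Compound 1 `COc1cc2occ(-c3csc4ccccc34)c(=O)c2c(OC)c1OC` and compound 2 `COc1cc2occ(-c3csc4ccccc34)c(=O)c2cc1OC` share one core; compound 3 `O=C(/C=C/c1csc2ccccc12)c1ccccc1O` and the unmeasured compound 4 `COc1ccc(C(=O)/C=C/c2csc3ccccc23)c(O)c1` share another. In a functional assay on A549 cells (Homo sapiens) for antiproliferative activity, read by sulforhodamine B assay, with a stated time of 72 h (a higher number here means a weaker inhibitor, a lower number a stronger inhibitor), compound 1 gives 640 nM. Compound 2 reaches only a limit in this assay, > 10000 nM, that is the limit of > 10000 nM in this assay, at which 1 of the 3 values shown sits. Compound 3 gives 5300 nM in this assay. The difference between the two cores is not broken down here. Compound 1 differs from compound 2 by methoxy in place of hydrogen on an aromatic carbon, a step of an at least 15-fold lower number from compound 2 to compound 1 (1.19 log units; beyond the scatter). Compound 4 differs from compound 3 by methoxy in place of hydrogen on an aromatic carbon, the same kind of change but not the same: the place is meta to a hydroxy group and para to a large group, rather than ortho to a fused ring and ortho to a methoxy group. In this assay the step from compound 3 to compound 4 is expected to be a 2.1-fold lower number from compound 3 to compound 4 (0.33 log units; beyond the scatter), more modest than the earlier step, which starts from a limit and stands alone. Compound 4 is thus estimated at 2500 nM, expected between 800 nM and 8000 nM.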

Compound 4, half-maximal inhibitory concentration: 5600 nM
The estimate for compound 4 lay 2.2-fold (0.35 log units) below the measured number; measured number inside the range.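

The new step reads a 1.1-fold higher number from compound 3 to compound 4 (0.02 log units; within the scatter), so at this place on this core, methoxy in place of hydrogen leaves the number in this assay within the scatter. The same change does not carry over from one core to the other: the same change on two cores in this assay, an at least 15-fold lower number (1.19 log units; beyond the scatter) from compound 2 to compound 1 and a 1.1-fold higher number (0.02 log units; within the scatter) from compound 3 to compound 4, at least 16-fold (1.21 log units) apart, beyond the scatter of two such steps. For the compounds shown here, this does not show that the core alone decides the outcome, as core and place change together, with the methoxy of compound 4 meta to a hydroxy group and para to a large group, and each core offers only one pair.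

Open, from the compounds shown here alone, is whether methoxy elsewhere on the same ring of compound 3 would give a larger step. Also open, going by these compounds, is whether an amine or a carboxylic acid at the place used in compound 4 would behave as methoxy does.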